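The source may report more compounds than this note shows. Statements on the series, on what has been measured and on what is new or still open speak of the compounds shown alone.

Measured compounds:
compound 1, `Cc1csc(NC(=O)c2cc(C(C)(C)C)nn2Cc2ccccc2)n1`, 4.7;
compound 2, `CC(C)(C)c1cc(C(=O)Nc2ccccn2)n(Cc2ccccc2)n1`, 4.5;
compound 3, `CC(C)(C)c1cc(C(=O)Nc2cccnc2)n(Cc2ccccc2)n1`, 3.8.

In a physicochemical assay for lipophilicity, read by HPLC, at pH 7.4 (a higher number here means a more lipophilic compound, a lower number a more polar compound), compound 3 stands lowest of the three, with compound 2 nearest and compound 1 furthest. Compound 4, `CNCc1csc(NC(=O)c2cc(C(C)(C)C)nn2Cc2ccccc2)n1`, differs from compound 3 in one place: 4-((methylamino)methyl)-1,3-thiazol-2-yl in place of pyridin-3-yl on an amide-type nitrogen. Going by the values given here, the only measured step that bears on this is the reverse of the thiazole-to-pyridine exchange, a number 0.90 log units lower from compound 1 to compound 3 (beyond the scatter), which would by itself point back up toward compound 1. Among the compounds with values here, no measured compound carries the methylaminomethyl group, so its effect in this assay is unknown from these data; such groups are usually less lipophilic than a plain methyl. The account therefore expects a downward step of a number 1.00 log units lower from compound 3 to compound 4 (beyond the scatter) for compound 4, with wide uncertainty, and estimates compound 4 at 2.8, between 1.8 and 3.8.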

Compound 4, distribution coefficient: 3.8
Compound 4: the middle estimate sits 1.00 log units below what was measured, and the stated range covers the measured number.
By their numbers in this assay, from the lowest: compounds 3 and 4 (each within the scatter of the next); then compounds 2 and 1 (each within the scatter of the next).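

In this assay, going by these compounds alone, methylamino in place of hydrogen on a saturated chain carbon bound to an aromatic carbon gives a number 0.90 log units lower from compound 1 to compound 4 (beyond the scatter), the first reading for this group at this position. Set against the pyridines on the amide-type nitrogen, the substituted thiazole gives no change at the digits printed from compound 3 to compound 4 (within the scatter) and a number 0.70 log units lower from compound 2 to compound 4 (beyond the scatter), so compound 4 matches compound 3 and not compound 2. Nothing available explains these steps. On these data alone, it remains open whether dimethylamino or a primary amine on the same chain carbon would give a similar step. As far as these compounds go, a longer chain carrying the methylamino group is equally open.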